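From Hydroxy to Ethylsulfonyl on the Nitrile-Bearing Ring

The compounds below may be only part of what the source reports. "The series", "measured", "known", "first", "only" and "open" are said of these compounds alone.

Compound 3 `Cc1ccc2ccc(-c3cc(O)cc(C#N)c3)cc2n1` is the weakest of the three measured compounds in a functional assay on CHO cells for inhibition of metabotropic glutamate receptor 5 (Rattus norvegicus), read by FLIPR and calcium flux (a higher number here means a weaker inhibitor, a lower number a stronger inhibitor), where compound 3 gives 360 nM. Compound 1 `Cc1ccc2ccc(-c3cccc(C#N)c3)cc2n1` gives 7.7 nM in this assay, and compound 2 `COc1cc(C#N)cc(-c2ccc3ccc(C)nc3c2)c1` gives 2.4 nM. The two steps leading to compound 3 were large: a 47-fold higher number from compound 1 to compound 3 (1.67 log units; beyond the scatter) and a 150-fold higher number from compound 2 to compound 3 (2.18 log units; beyond the scatter). By contrast, a 3.2-fold lower number from compound 1 to compound 2 (0.51 log units; beyond the scatter). Compound 4 `CCS(=O)(=O)c1cc(C#N)cc(-c2ccc3ccc(C)nc3c2)c1` differs from compound 3 in one respect: ethylsulfonyl in place of hydroxy on an aromatic carbon. Among the measured compounds, the hydroxy group goes with the highest number, while hydrogen and methoxy in that place give far lower numbers. For the measured compounds named here, replacing the hydroxy is therefore expected to lower the number again, though no measured compound carries an ethylsulfonyl group, so the size of the gain is uncertain. The expected step is a 9.0-fold lower number from compound 3 to compound 4 (0.95 log units; beyond the scatter). Compound 4 is estimated at 40 nM in this assay, with a range from 5 nM to 300 nM.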

Compound 4, half-maximal inhibitory concentration: 1090 nM
Beside the measured number, compound 4's estimate is 27-fold (1.44 log units) below it; measured number above the stated range.
By their numbers in this assay, from the lowest: compound 2; then compound 1; then compound 3; then compound 4.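

In this assay the change brought a 3.0-fold higher number from compound 3 to compound 4 (0.48 log units; beyond the scatter) and not a return toward the low numbers, and the distance to the other groups on this aromatic carbon is large, with a 140-fold higher number from compound 1 to compound 4 (2.15 log units; beyond the scatter) on going from hydrogen and a 450-fold higher number from compound 2 to compound 4 (2.66 log units; beyond the scatter) on going from methoxy at this same place. For the compounds shown here, the earlier compounds left hydroxy, the only group here with a hydrogen-bond donor, with the highest number, but ethylsulfonyl has no such donor and stands higher still, so a donor alone does not sort these four compounds. Nothing available here explains the rise.

The compounds shown leave open whether the rise follows the sulfonyl unit or its ethyl chain, which a methylsulfonyl or an ethoxy group in this place would help separate. They also leave open how an amine or a carboxylic acid would fare on this carbon.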